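Swapping 4-hydroxyphenyl for 3-chlorophenyl

This account rests on a few compounds, and the source may have more. Where it says the series, first, only, none or still open, it means among the compounds named here.

Among the compounds with values here, in a functional assay on EOL1 cells (Homo sapiens) for inhibition, read by fluorescence, with a stated time of 72 h (a higher number here means a weaker inhibitor of growth, a lower number a stronger inhibitor of growth), compound 3 `CCCCCCn1cnc2c(Nc3ccc(O)cc3)nc(N[C@H]3CC[C@H](N)CC3)nc21` gives 190 nM, the lowest number of the three so far. Compound 1 `CCCCCCn1cnc2c(Nc3ccc(Cl)cc3)nc(N[C@H]3CC[C@H](N)CC3)nc21` gives 440 nM and compound 2 `COc1ccc(Cn2cnc3c(Nc4cccc(Cl)c4)nc(N[C@H]4CC[C@H](N)CC4)nc32)cc1` gives 530 nM, both beyond the scatter from compound 3. Compound 4 `CCCCCCn1cnc2c(Nc3cccc(Cl)c3)nc(N[C@H]3CC[C@H](N)CC3)nc21` has 3-chlorophenyl in place of 4-hydroxyphenyl on a nitrogen on an aromatic ring. The nearest evidence is a 2.3-fold lower number from compound 1 to compound 3 (0.36 log units; beyond the scatter), a modest step in which hydroxy replaced chloro on an aromatic carbon. Within the data shown here, no measured step isolates the 3-chlorophenyl group itself, although compound 2 also carries it. Going back from hydroxy to chlorine, a modest rise in this assay is expected. The expected step is a 2.2-fold higher number from compound 3 to compound 4 (0.34 log units; beyond the scatter). The estimate for compound 4 is 420 nM, with an expected range of 190 nM to 900 nM.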

Compound 4, concentration for 50% growth inhibition: 310 nM
Estimate against measurement, compound 4: 1.4-fold (0.13 log units) above, within the range that was stated.
By their numbers in this assay, from the lowest: compounds 3, 4, 1 and 2 (each within the scatter of the next, the first and the last beyond it).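

In this assay, the 3-chlorophenyl group on this nitrogen can stand in for 4-hydroxyphenyl, with a 1.6-fold higher number from compound 3 to compound 4 (0.21 log units; within the scatter), and for 4-chlorophenyl, with a 1.4-fold lower number from compound 1 to compound 4 (0.15 log units; within the scatter), so neither change clearly separates the compounds. With 3-chlorophenyl held fixed, pentyl in place of 4-methoxyphenyl on the saturated chain carbon gives a 1.7-fold lower number from compound 2 to compound 4 (0.23 log units; within the scatter), which also fails to separate them. No supporting measurement is available to explain these results. Still open, on these data alone, is whether a 3-hydroxyphenyl or 4-aminophenyl group on this nitrogen, or a longer chain in place of pentyl, would give a clearer difference.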